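Amino-to-chloro swap on the purine-like core of compound 2

This account rests on a few compounds, and the source may have more. Where it says the series, first, only, none or still open, it means among the compounds named here.

Three compounds of this series have a number in a functional assay on U-251 cells (Homo sapiens) for cytotoxicity, read by sulforhodamine B assay, with a stated time of 48 h; on this read-out lower numbers stand for higher toxicity in this test and higher numbers for lower toxicity in this test. Compound 1 `ClCc1ccc(Cn2cnc3c(Cl)ncnc32)cc1` gives 7410 nM, and compound 3 `ClCc1ccccc1Cn1cnc2nc(Cl)nc(Cl)c21` gives 3630 nM. Compound 2 `Nc1nc(Cl)c2ncn(Cc3ccccc3CCl)c2n1` gives 72400 nM, the highest of the three numbers; its nearest neighbour is compound 1, its furthest compound 3, and both gaps lie beyond the scatter. Compound 4 `ClCc1ccccc1Cn1cnc2c(Cl)nc(Cl)nc21` has not yet been measured in this assay. It differs from compound 2 in one place: chloro in place of amino on an aromatic carbon. Compound 3 already carries two chloro groups on its core, as compound 4 would, and its number sits well under that of compound 2. Among the measured compounds shown here, on that ground the step from compound 2 to compound 4 is expected to move toward a lower number, with an estimated step of a 14-fold lower number from compound 2 to compound 4 (1.16 log units; beyond the scatter), though no measured pair shows this exact change. Compound 4 is therefore estimated at 5000 nM, with a range from 1500 nM to 20000 nM in this assay.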

Compound 4, concentration lethal to 50% of the cells: 4570 nM
Compound 4: the middle estimate sits 1.1-fold (0.04 log units) above what was measured, within the range that was stated.
By their numbers in this assay, from the lowest: compounds 3, 4 and 1 (each within the scatter of the next, the first and the last beyond it); then compound 2.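

In this assay, chloro in place of amino on the aromatic carbon between two ring nitrogen atoms gives a 16-fold lower number from compound 2 to compound 4 (1.20 log units; beyond the scatter), so this one position alone can shift the number by a large step. The earlier compounds shown here included no pair differing in one place, and the high number of compound 2 could not be tied to any single group until now. Nothing measured here explains the size of this step.

As far as these compounds go, whether the step reflects the arrival of chloro or the loss of amino stays open, and a methoxy group, a methyl group or a plain hydrogen at this position would help separate the two. Among the compounds shown here, also open is whether the same swap gives a similar step elsewhere, as only this one pair shows it.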